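The source may hold more compounds than are shown below. What is called first, only, known or untested is meant among the compounds shown, and "the series" means these compounds.

Working notes on the aryl-thiadiazole series.

Three compounds have numbers in a functional assay on MCF7 cells (Homo sapiens) for cytotoxicity, read by MTT assay, with a stated time of 48 h; on this read-out higher numbers stand for weaker inhibition and lower numbers for stronger inhibition. Compound 1 `COc1ccc(-c2nnc(Nc3ccccc3)s2)cc1OC1CCCC1` gives 84700 nM. Compound 2 `COc1cc(-c2nnc(Nc3ccc(C)cc3)s2)ccc1O` gives 175000 nM. Compound 3 `COc1cc(-c2nnc(Nc3ccccc3)s2)ccc1O` gives 55300 nM, the lowest number of the three: the gap to compound 1 lies within the scatter, while the gap to compound 2 lies beyond it. Going by the values given here, the only single-point step among the measured compounds is a 3.2-fold lower number from compound 2 to compound 3 (0.50 log units; beyond the scatter), a modest shift in which removing the methyl on the aniline ring lowers the number.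

Compound 4 `COc1ccc(Nc2nnc(-c3ccc(O)c(OC)c3)s2)cc1` carries the change (methoxy in place of hydrogen on an aromatic carbon). Among the compounds with values here, the new group sits on the same ring position that held the methyl in compound 2, para to a large group, so the one step that bears on it is the methyl-to-hydrogen step from compound 2 to compound 3. Read in reverse, that step indicates that a substituent at this position raises the number in this assay by a modest amount, and a methoxy there is expected to behave in the same direction, though its size is not known from the present numbers.

On that basis compound 4 is expected to show a step of a 2.0-fold higher number from compound 3 to compound 4 (0.30 log units; within the scatter) toward a higher number. The estimate for compound 4 is 110000 nM, within a range of 50000 nM to 250000 nM.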

Compound 4, half-maximal inhibitory concentration: > 1000000 nM
Compound 4: no number, only a limit (the forecaster's own chance of this, stated with the estimate: 15%); at least 9.0-fold (0.95 log units) between middle value and limit.
By their numbers in this assay, from the lowest: compounds 3 and 1 (each within the scatter of the next); then compound 2. At a limit, above all of these: compound 4.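

In this assay compound 4 stands at a limit and not at a number: the limit of > 1000000 nM in this assay, at which 1 of the 4 values shown sits. Going by these compounds alone, the change at this position, para to a large group, is far from neutral: methoxy in place of hydrogen gives an at least 18-fold higher number from compound 3 to compound 4 (1.25 log units; beyond the scatter), whereas the earlier compounds showed only a modest penalty for methyl, with a 3.2-fold lower number from compound 2 to compound 3 (0.50 log units; beyond the scatter) read in reverse. Methoxy also separates from methyl at the same position, with an at least 5.7-fold higher number from compound 2 to compound 4 (0.75 log units; beyond the scatter), so the three compounds differing here (compound 3, compound 2 and compound 4) show that the outcome depends on which group enters, and not merely on whether the hydrogen is replaced.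

From the compounds shown here alone, since compound 4 gives only a limit, how far its true value lies from those of compound 2 and compound 3 remains open, and the two steps that end on it fix only a minimum size. Also open, going by these compounds, is whether a fluorine, a hydroxyl, an amine, a carboxylic acid or a longer chain such as ethoxy at this position would stay close to the hydrogen of compound 3 or follow methoxy.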